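A few compounds are considered here, and "the series" means these few. Any claim that something is new, unique, unknown or untested is made for them only; others in the source may bear on it.

Three chalcones sharing a fluorophenyl ketone were compared in a functional assay on A549 cells (Homo sapiens) for cytotoxicity, read by MTT assay, with a stated time of 72 h; on this read-out lower numbers stand for stronger inhibition and higher numbers for weaker inhibition. Compound 1, `COc1cc(/C=C/C(=O)c2ccccc2F)cc(OC)c1OC`, gives > 100000 nM, which is a limit of the assay and not a number (the limit of > 100000 nM in this assay, at which 1 of the 3 values shown sits). Compound 2, `COc1cc(OC)c(OC)cc1/C=C/C(=O)c1ccccc1F`, gives 79 nM in this assay. Compound 3, `COc1ccc(OC)c(/C=C/C(=O)c2ccccc2F)c1`, gives 114 nM in this assay. The difference between the core of compound 1 and the core of compound 3 is not broken down here.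

Compounds 3 and 2 differ in one place: methoxy in place of hydrogen on an aromatic carbon. That change gave a 1.4-fold lower number from compound 3 to compound 2 (0.16 log units; within the scatter), so the two values cannot be ordered.

Compound 4, `COc1ccc(C(=O)/C=C/c2cc(OC)c(OC)c(OC)c2)c(F)c1`, has not yet been measured in this assay. It differs from compound 1 by methoxy in place of hydrogen on an aromatic carbon. This is the same kind of change as that from compound 3 to compound 2, but not the same: there the entering group sat ortho to a methoxy group and meta to a methoxy group, whereas here it sits meta to a fluoro group, and the change now falls on the other aromatic ring.

For compound 4 the expected step is an at least 2.5-fold lower number from compound 1 to compound 4 (0.39 log units; beyond the scatter), resting on compound 1 at > 100000 nM and on the small size of a 1.4-fold lower number from compound 3 to compound 2 (0.16 log units; within the scatter), which suggests that one methoxy group alone seldom moves the read-out far. Compound 4 is therefore estimated at 40000 nM, expected to lie between 3000 nM and 100000 nM.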

Compound 4, half-maximal inhibitory concentration: 108 nM
Estimate against measurement, compound 4: 370-fold (2.57 log units) above; measured number outside the range, below it.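

In this assay methoxy in place of hydrogen on an aromatic carbon, here meta to a fluoro group and para to a large group, gave an at least 920-fold lower number from compound 1 to compound 4 (2.96 log units; beyond the scatter) and so the size of this change did not carry over from one core to the other: the same change on two cores in this assay, a 1.4-fold lower number (0.16 log units; within the scatter) from compound 3 to compound 2 and an at least 920-fold lower number (2.96 log units; beyond the scatter) from compound 1 to compound 4, at least 640-fold (2.80 log units) apart, beyond the scatter of two such steps.
As far as these compounds go, compound 1 gives > 100000 nM and this is a limit of the assay and not a number, so the full size of the step stays unknown: the limit of > 100000 nM in this assay, at which 1 of the 4 values shown sits.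
The two steps also differ in which aromatic ring takes the methoxy group and in the groups around it, and the data do not separate these differences from the change of core, so they show that the change does not transfer reliably here but give no rule for predicting its size on another core.

The compounds shown leave open whether a methoxy group is specifically required at this place on the fluorophenyl ring of compound 4, or whether a hydroxy group, an ethoxy group or a chlorine atom there would give a similar value. Also open, from the compounds shown here alone, is what would happen if hydrogen took the place of the fluoro group in compound 4, or if an amine took the place of one of the methoxy groups on its other ring.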